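The source may report more compounds than this note shows. Statements on the series, on what has been measured and on what is new or still open speak of the compounds shown alone.

Measured in a functional assay on OVCAR-3 cells (Homo sapiens) for antiproliferative activity, read by spectrophotometry, with a stated time of 2 days; on this read-out lower numbers stand for stronger inhibition of growth and higher numbers for weaker inhibition of growth:
- Compound 1 `Cc1ccc(Nc2ncc(C(F)(F)F)c(N3Cc4cccc(N(C)S(C)(=O)=O)c4C3)n2)cc1C`: > 30000 nM, a limit
- Compound 2 `Cc1ccc(Nc2ncc(C(F)(F)F)c(N3Cc4cccc(N(C)S(C)(=O)=O)c4C3)n2)c(Cl)c1`: > 30000 nM, a limit

In this assay compound 2 gives > 30000 nM, which is a limit and not a number. Among the compounds with values here, the same holds for its only measured neighbour: the limit of > 30000 nM in this assay, at which 2 of the 2 values shown sit. Within the data shown here, the one measured step, a step that the two limits leave unreadable from compound 1 to compound 2, changes the same aryl group but has no readable size, so it offers no measure for the next change.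

Compound 3 `COc1cc(Nc2ncc(C(F)(F)F)c(N3Cc4cccc(N(C)S(C)(=O)=O)c4C3)n2)c(OC)cc1Cl` differs from compound 2 as follows: 4-chloro-2,5-dimethoxyphenyl in place of 2-chloro-4-methylphenyl on a nitrogen on an aromatic ring. Among the measured compounds shown here, no measured step shows a gain from changing this group, so no clear shift is expected in this assay, and a second limit reading is likely. Compound 3 is estimated at 30000 nM, with an expected range of 6000 nM to 60000 nM. The expected step is a number no higher from compound 2 to compound 3 (the limit leaves the size open).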

Compound 3, concentration for 50% growth inhibition: > 30000 nM
Compound 3 ended at the assay's limit; the forecaster's own chance of this, stated with the estimate: 75%; the middle value lies on the limit itself.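

Compound 3, like compound 1 and compound 2, gives only a limit and not a number in this assay, so no step among these three compounds can be read: the limit of > 30000 nM in this assay, at which 3 of the 3 values shown sit.

The compounds shown leave open whether any aryl group on the shared core gives a readable value in this assay, and how these three groups rank.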